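From Compound 2 to Compound 3: One Group Exchanged

The source may hold more compounds than are shown below. What is called first, only, known or untested is meant among the compounds shown, and "the series" means these compounds.

In a functional assay on HT-29 cells (Homo sapiens) for inhibition, read by CellTiter-Glo, with a stated time of 72 h (on this read-out lower numbers stand for higher toxicity in this test and higher numbers for lower toxicity in this test), compound 1 `CC1=C(CC(=O)N2CCN(CCCN(C)C)CC2)c2cc(F)ccc2/C1=C\c1ccc([S+](C)[O-])cc1` gives 23800 nM and compound 2 `CC1=C(CC(=O)N2CCN(c3ccncc3)CC2)c2cc(F)ccc2/C1=C\c1ccc([S+](C)[O-])cc1` gives 9200 nM as its result. Going by the values given here, compound 2 therefore holds the lower of the only two numbers so far, which means the higher toxicity in this test.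

Compound 3 `CC1=C(CC(=O)N2CCN(c3ccncc3)CC2)c2cc(F)ccc2/C1=C\c1nc2ccccc2s1` keeps the pyridin-4-yl of compound 2 and differs elsewhere, with a group of 9 heavy atoms (7 carbon, 1 nitrogen, 1 sulfur; one five-membered aromatic ring with 2 hetero atoms, one six-membered aromatic ring of carbon only) in place of a group of 9 heavy atoms (7 carbon, 1 oxygen, 1 sulfur; one six-membered aromatic ring of carbon only), on a double-bonded chain carbon bound to a double-bonded ring carbon as the change. The entering group is 1,3-benzothiazol-2-yl.

Among the compounds with values here, the only measured step is a 2.6-fold lower number from compound 1 to compound 2 (0.41 log units; beyond the scatter) and it lies at a different place in the molecule. Within the data shown here, no measurement yet shows what a change at the new place does, so that step serves only as a rough guide to size. A modest move toward a lower number is expected in this assay but the direction is uncertain. The expected step is a 2.3-fold lower number from compound 2 to compound 3 (0.36 log units; beyond the scatter) and this remains a tentative estimate. Compound 3 is estimated at 4000 nM with 1300 nM to 13000 nM as the expected range of this estimate.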

Compound 3, half-maximal cytotoxic concentration: 5250 nM
Beside the measured number, compound 3's estimate is 1.3-fold (0.12 log units) below it, within the range that was stated.
By their numbers in this assay, from the lowest: compounds 3 and 2 (each within the scatter of the next); then compound 1.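

With this assay as the measure, putting 1,3-benzothiazol-2-yl in place of the group with a single six-membered aromatic ring of carbon gives a 1.8-fold lower number from compound 2 to compound 3 (0.24 log units; within the scatter) and offers the first view of the place on a double-bonded chain carbon bound to a double-bonded ring carbon. Although the entering group brings a five-membered aromatic ring with 2 hetero atoms and the heavy-atom count stays the same, this test cannot tell compound 2 and compound 3 apart, whereas the change on the amine nitrogen in a ring gave a 2.6-fold lower number from compound 1 to compound 2 (0.41 log units; beyond the scatter) and so did register. No measurement at hand offers a reason for this result.

Going by these compounds, whether a plain phenyl, or an aromatic ring carrying an amine or a carboxylic acid, would shift the number beyond the scatter at this same place remains open. Also open, on these data alone, is whether 1,3-benzothiazol-2-yl would give a similar result with the 3-(dimethylamino)propyl of compound 1 in place of the pyridin-4-yl of compound 3.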